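Swapping the aryl ether for a branched alkyl chain

The compounds below may be only part of what the source reports. "The series", "measured", "known", "first", "only" and "open" are said of these compounds alone.

Compound 1 `Fc1ccc(Oc2ccc3c(NCCCNCc4ccco4)ccnc3c2)cc1` shares its core and its amine-bearing chain with two measured partners, compound 2 `CC(C)(C)c1ccc(Oc2ccc3c(NCCCNCc4ccco4)ccnc3c2)cc1` and compound 3 `COc1ccc(F)cc1CNCCCNc1ccnc2cc(Oc3ccc(F)cc3)ccc12`. In a physicochemical assay for acid dissociation, compound 1 gives 9.28, compound 2 gives 9.28 and compound 3 gives 9.28, so compound 1 stands level with both at the digits shown. The step of no change at the digits printed from compound 1 to compound 2 (within the scatter) and the step of no change at the digits printed from compound 1 to compound 3 (within the scatter) were both flat: neither a change on the outer aromatic ring nor a change at the end of the chain moved the value.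

Compound 4 `CCC(CC)c1ccc2c(NCCCNCc3ccco3)ccnc2c1` has not yet been measured. It differs from compound 1 in one place: pentan-3-yl in place of 4-fluorophenoxy on an aromatic carbon. Of the measured steps, no change at the digits printed from compound 1 to compound 2 (within the scatter) bears most on this, as it also alters the fluorophenoxy part of compound 1, and it showed nothing beyond the scatter. A step of a number 0.02 log units higher from compound 1 to compound 4 (within the scatter) is therefore expected in this assay, none beyond the scatter. Compound 4 is estimated at 9.3, between 9 and 9.6.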

Compound 4, acid dissociation constant: 9.47
Compound 4: the middle estimate sits 0.17 log units below what was measured, within the range that was stated.
By their numbers in this assay, from the lowest: compounds 1, 2, 3 and 4 (each within the scatter of the next).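

Compound 2 changed only the fluoro of the 4-fluorophenoxy group, whereas compound 4 loses the whole group, including its six-membered aromatic ring and its hydrogen-bond acceptor, and carries pentan-3-yl on that aromatic carbon instead. In this assay this much larger replacement gives a number 0.19 log units higher from compound 1 to compound 4 (within the scatter) and so, like the smaller changes, does not move the read-out beyond the scatter. This widens the finding from a change within the group to a replacement of the entire group, but no evidence is available on what lies behind the result.

Still open, going by these compounds, is whether a different group on this aromatic carbon, such as an amine, a carboxylic acid or a nitrile, would shift the value beyond the scatter. Also open, on these data alone, is whether pentan-3-yl would behave the same way with 5-fluoro-2-methoxyphenyl, the group in compound 3, in place of furan-2-yl.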